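Swapping Aminothiazole for Imidazole in a Histamine Agonist Series

The compounds below may be only part of what the source reports. "The series", "measured", "known", "first", "only" and "open" are said of these compounds alone.

Compound 1 `Cc1nc(N)sc1CCCNC(=N)NC(=O)C[C@@H](C)c1ccccc1` gives 53.7 nM in an in vitro functional assay on Sf9 cells for agonist activity at histamine H2 receptor (Homo sapiens), read by GTPgammaS binding (on this read-out lower numbers stand for an effect already at smaller amounts and higher numbers for an effect only at larger amounts of compound), the upper of the two numbers recorded, with compound 2 within the usual scatter of it. Compound 2 `Cc1nc(N)sc1CCCNC(=N)NC(=O)C[C@H](C)C1CCCCC1` gives 28.8 nM, and the step of a 1.9-fold lower number from compound 1 to compound 2 (0.27 log units; within the scatter) alters only the far end of the chain. Compound 3 `C[C@H](CC(=O)NC(=N)NCCCc1c[nH]cn1)c1ccccc1` differs from compound 1 at another place: 1H-imidazol-4-yl in place of 2-amino-4-methyl-1,3-thiazol-5-yl on a saturated chain carbon, three bonds along the chain from an amine nitrogen. Among the measured compounds shown here, no measured step concerns this part of the molecule, so the single recorded step offers no direct guide. Compound 3 is expected to give 150 nM, within 50 nM to 500 nM. The estimated step of a 2.8-fold higher number from compound 1 to compound 3 (0.45 log units; beyond the scatter) is a modest weakening, uncertain in both directions.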

Compound 3, half-maximal effective concentration: 120 nM
Beside the measured number, compound 3's estimate is 1.3-fold (0.10 log units) above it; the measured number falls inside the stated range.
By their numbers in this assay, from the lowest: compounds 2 and 1 (each within the scatter of the next); then compound 3.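

Placing 1H-imidazol-4-yl where compound 1 carries 2-amino-4-methyl-1,3-thiazol-5-yl gives the first reading at this position: in this assay there is a 2.2-fold higher number from compound 1 to compound 3 (0.35 log units; beyond the scatter). The number at this end of the molecule therefore responds to the choice of ring, but only modestly, and the 2-amino-4-methyl-1,3-thiazol-5-yl group gives the lower number of the pair. Nothing on hand offers a reason for this step.

As far as these compounds go, it remains open whether the amino group or the methyl group of that ring accounts for the step. From the compounds shown here alone, how a pyridine ring would read at this position, and whether the imidazole swap gives a similar step with the 1-cyclohexylethyl end of compound 2, also remain open.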